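Ring Swap on the Five-Membered Aromatic Ring

The source may report more compounds than this note shows. Statements on the series, on what has been measured and on what is new or still open speak of the compounds shown alone.

Of the compounds shown here, two have so far been measured in an assay on isolated protein for inhibition of sphingosine kinase 1 (Homo sapiens); on this read-out higher numbers stand for weaker inhibition and lower numbers for stronger inhibition. Compound 1 `O=C(NCc1ccc(-c2noc(CCC3CC3)n2)cc1)[C@H]1NCC[C@@H]1O` gives 5000 nM, the highest of the two numbers. Compound 2 `CC[C@H](NC(=O)[C@H]1NCC[C@@H]1O)c1ccc(-c2noc(CCC3CCCC3)n2)cc1` gives 56 nM, a lower number beyond the scatter, but it differs from compound 1 in more than one place, so no single step can be read from the pair. Compound 3 `O=C(NCc1ccc(-c2noc(C3CCCCC3)n2)cc1)[C@H]1NCC[C@@H]1O` carries cyclohexyl in place of 2-cyclopropylethyl on an aromatic carbon. For the measured compounds named here, with no comparable step measured, a change of modest size in either direction, possibly none beyond the scatter, is expected for the step of a 1.7-fold lower number from compound 1 to compound 3 (0.22 log units; within the scatter). Compound 3 is therefore estimated at 3000 nM, within 800 nM to 12000 nM.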

Compound 3, half-maximal inhibitory concentration in the sphingosine kinase 1 assay: 380 nM
Compound 3: middle estimate off by 7.9-fold (0.90 log units), on the high side; measured number outside the range, below it.
By their numbers in the sphingosine kinase 1 assay, from the lowest: compound 2; then compound 3; then compound 1.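

Cyclohexyl in place of 2-cyclopropylethyl on an aromatic carbon gives, in the sphingosine kinase 1 assay, a 13-fold lower number from compound 1 to compound 3 (1.12 log units; beyond the scatter), the first single step that can be read at this position. Neither group carries hydrogen-bond donors, hydrogen-bond acceptors or a net charge, so a swap between two all-carbon groups is enough to move the number beyond the scatter. In a physicochemical assay for solubility, at pH 7.4 (on this read-out lower numbers stand for lower solubility and higher numbers for higher solubility), compound 1 gives > 50 ug/mL, which is a limit of the assay and not a number. In the physicochemical assay compound 3 gives > 50 ug/mL, which is also a limit of the assay and not a number. In the physicochemical assay the same step cannot be read: the limit of > 50 ug/mL in the physicochemical assay, at which 2 of the 2 values shown sit.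

The compounds shown do not separate ring size from the chain that links the ring in 2-cyclopropylethyl. On these data alone, whether a phenyl ring or an amine on this carbon would keep the lower number also stays open.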